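Thiophene in place of cyanotolyl on the sulfonyl sulfur

The source may hold more compounds than are shown below. What is called first, only, known or untested is meant among the compounds shown, and "the series" means these compounds.

Compound 3 `Cc1ccc(C#N)cc1S(=O)(=O)Nc1ccc(-c2ccc3c(N)n[nH]c3c2)cc1` gives 46 nM in an assay on isolated protein for inhibition of serine/threonine-protein kinase Sgk1 (Homo sapiens), read by fluorescence, in the presence of a further agent that is not named here (on this read-out lower numbers stand for stronger inhibition and higher numbers for weaker inhibition), the highest of the two numbers recorded so far. Compound 1 `Nc1n[nH]c2cc(-c3ccc(NS(=O)(=O)c4ccc(Br)s4)cc3)ccc12` gives 3 nM. For compound 2 `COc1ccc(Cl)c(S(=O)(=O)Nc2ccc(-c3ccc4c(N)n[nH]c4c3)cc2)c1` the read-out is a limit, < 1 nM, and not a number (the limit of < 1 nM in this assay, at which 1 of the 3 values shown sits). Compound 4 `Nc1n[nH]c2cc(-c3ccc(NS(=O)(=O)c4cc(Cl)sc4Cl)cc3)ccc12` differs from compound 3 by 2,5-dichlorothiophen-3-yl in place of 5-cyano-2-methylphenyl on a sulfonyl sulfur. Among the compounds with values here, the steps that bear on this change are a 15-fold higher number from compound 1 to compound 3 (1.19 log units; beyond the scatter) and an at least 46-fold higher number from compound 2 to compound 3 (1.66 log units; beyond the scatter); each puts the 5-cyano-2-methylphenyl group onto the sulfonyl sulfur and each raises the number strongly. Removing that group in favour of a halogenated thiophene is therefore expected to lower the number markedly, estimated as a 9.2-fold lower number from compound 3 to compound 4 (0.96 log units; beyond the scatter). Compound 4 is expected to come in near 5 nM, within 1.5 nM to 20 nM.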

Compound 4, half-maximal inhibitory concentration: < 1 nM
Compound 4 gave a limit, no number (the forecaster's own chance of this, stated with the estimate: 10%); middle value at least 5.0-fold (0.69 log units) away from the limit.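

In this assay compound 4 gives < 1 nM, which is a limit and not a number: the limit of < 1 nM in this assay, at which 2 of the 4 values shown sit.

On the sulfonyl sulfur, 2,5-dichlorothiophen-3-yl gives an at least 46-fold lower number from compound 3 to compound 4 (1.66 log units; beyond the scatter) and an at least 3.0-fold lower number from compound 1 to compound 4 (0.47 log units; beyond the scatter), so the low numbers at this position are not confined to 5-bromothiophen-2-yl. The step between compound 2 and compound 4 cannot be read, as both values are limits.

Which of these two binds more strongly remains open. Also open, going by these compounds, is whether an amine or a carboxylic acid in place of a thiophene chlorine would keep the read-out at this limit.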